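Semicarbazone aryl variation on a fixed core

The compounds below may be only part of what the source reports. "The series", "measured", "known", "first", "only" and "open" are said of these compounds alone.

Measured:
Compound 1, `COc1ccc(/C=N/NC(=O)Nc2ccc(Oc3ccnc(-c4nncn4CCN(C)C)c3)c(F)c2)c(OC)c1`, 1780 nM in a functional assay on HT-29 cells (Homo sapiens) for cytotoxicity, read by MTT assay, with a stated time of 72 h; on this read-out lower numbers stand for stronger inhibition and higher numbers for weaker inhibition.
Compound 2, `COc1cc(/C=N/NC(=O)Nc2ccc(Oc3ccnc(-c4nncn4CCN(C)C)c3)c(F)c2)cc(OC)c1OC`, 3620 nM in this assay.

Among the compounds with values here, compound 2 gives the highest of the two numbers in this assay; its nearest neighbour is compound 1, and the single measured step is a 2.0-fold higher number from compound 1 to compound 2 (0.31 log units; beyond the scatter). Compound 3, `COc1ccc(/C=N/NC(=O)Nc2ccc(Oc3ccnc(-c4nncn4CCN(C)C)c3)c(F)c2)cc1O`, carries the change (3-hydroxy-4-methoxyphenyl in place of 3,4,5-trimethoxyphenyl on a carbon with a double bond to nitrogen). Within the data shown here, only that one step bears on it, and it shows that swapping methoxy patterns on this aryl moves the number modestly. Returning toward fewer methoxy groups, with one hydroxyl entering, compound 3 is expected to give 2200 nM within 900 nM to 5500 nM, a step of a 1.6-fold lower number from compound 2 to compound 3 (0.22 log units; within the scatter) expected only near the edge of scatter.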

Compound 3, half-maximal inhibitory concentration: 960 nM
Compound 3: middle estimate off by 2.3-fold (0.36 log units), on the high side; measured number inside the range.
By their numbers in this assay, from the lowest: compounds 3 and 1 (each within the scatter of the next); then compound 2.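

In this assay, the carbon with a double bond to nitrogen accepts a hydroxyl-bearing aryl group: 3-hydroxy-4-methoxyphenyl in place of 3,4,5-trimethoxyphenyl gives a clear step (a 3.8-fold lower number from compound 2 to compound 3 (0.58 log units; beyond the scatter)). Against 2,4-dimethoxyphenyl, the same group gives no separation (a 1.9-fold lower number from compound 1 to compound 3 (0.27 log units; within the scatter)), so compound 1 and compound 3 cannot be ranked. No measurement at hand explains these steps.

From the compounds shown here alone, whether the hydroxyl or the loss of a methoxy group carries the step from compound 2 stays open, as the change alters both at once. Going by these compounds, how an amine or a carboxylic acid on this aryl ring would read is also open.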